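The source may report more compounds than this note shows. Statements on the series, on what has been measured and on what is new or still open speak of the compounds shown alone.

Measured in the series:

- compound 1, `O=C(CCCCC1CCSS1)NCc1cn(CCCOc2ccc3ccc(=O)oc3c2)nn1`: in a functional assay on PC-12 cells (Rattus norvegicus) for cytotoxicity, read by MTT assay, with stated times of 3 h and 2 h, tested at 0.1 uM (a higher number here means a stronger effect of the compound at the concentration tested, a lower number a weaker effect), compound 1 gives 37.8%
- compound 2, `CCOC(=O)c1cc2ccc(OCCCn3cc(CNC(=O)CCCCC4CCSS4)nn3)cc2oc1=O`: in this assay compound 2 gives 28%
- compound 3, `O=C(CCCCC1CCSS1)NCc1cn(CCCOc2ccc3cc(-c4ccc(Br)cc4)c(=O)oc3c2)nn1`: in this assay compound 3 gives 39.5%

Compound 3 carries the highest of the three numbers, but its separation from compound 1 is a number 1.7 percentage points higher from compound 1 to compound 3 (within the scatter), so the two cannot be ordered. Among the compounds with values here, the only step beyond the scatter is a number 11.5 percentage points higher from compound 2 to compound 3 (beyond the scatter); the remaining step, a number 9.8 percentage points lower from compound 1 to compound 2 (within the scatter), is within the scatter.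

Compound 4, `O=C(CCCCC1CCSS1)NCc1cn(CCCOc2ccc3cc(-c4ccc(Cl)c(Cl)c4)c(=O)oc3c2)nn1`, is the next member. It differs from compound 3 as follows: 3,4-dichlorophenyl in place of 4-bromophenyl on an aromatic carbon.

Bearing on this change are the steps that alter the same aromatic carbon of the shared core. Adding 4-bromophenyl to hydrogen gave a number 1.7 percentage points higher from compound 1 to compound 3 (within the scatter), a null result; replacing ethoxycarbonyl by 4-bromophenyl gave a number 11.5 percentage points higher from compound 2 to compound 3 (beyond the scatter), the only modest movement. Within the data shown here, no measured step exchanges one substituted phenyl for another at this place, so there is nothing to suggest that 3,4-dichlorophenyl in place of 4-bromophenyl should move the read-out in either direction.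

Compound 4 is therefore expected to give 39% in this assay, estimated between 28% and 50%. This estimate implies a number 0.5 percentage points lower from compound 3 to compound 4 (within the scatter), a step expected to stay within the scatter.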

Compound 4, a percentage reported as activity, at one concentration (the size of the read-out at that concentration, not a potency): 38.1%
Beside the measured number, compound 4's estimate is 0.9 percentage points above it, within the range that was stated.
By their numbers in this assay, from the lowest: compounds 2, 1, 4 and 3 (each within the scatter of the next, the first and the last beyond it).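

Within the data shown here, exchanging one substituted phenyl for another at this aromatic carbon, a change no earlier step covered, gives a number 1.4 percentage points lower from compound 3 to compound 4 (within the scatter) in this assay, so 3,4-dichlorophenyl and 4-bromophenyl cannot be told apart by this read-out. Set against hydrogen, the new group gives a number 0.3 percentage points higher from compound 1 to compound 4 (within the scatter), and set against ethoxycarbonyl it gives a number 10.1 percentage points higher from compound 2 to compound 4 (beyond the scatter), so a second substituted phenyl now shows the same picture as 4-bromophenyl: no readable change from hydrogen and a modest separation from the ester, although compound 1 itself remains within the scatter of compound 2. The data shown offer no measured explanation for this behaviour at this carbon.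

As far as these compounds go, what remains open is whether an amine or a carboxylic acid on this aromatic carbon would stay in the range shared by hydrogen and the two substituted phenyls, or move away from it. Also open, from the compounds shown here alone, is whether compound 1, compound 3 and compound 4, which this single-concentration read-out does not separate, would show a stronger or weaker effect relative to one another at other concentrations.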